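Shortening a bromoalkyl chain on a cytotoxicity-inactive scaffold

The source may hold more compounds than are shown below. What is called first, only, known or untested is meant among the compounds shown, and "the series" means these compounds.

Four compounds are considered here, each carrying two styryl-type arms on a shared core, with a bromine-tipped alkoxy chain attached to that core. Compound 1 has the structure `COc1ccc(/C=C/c2cc(/C=C/c3ccc(OC)c(OC)c3)nc(OCCCCCCBr)n2)cc1OC` and compound 2 the structure `COc1ccc(/C=C/c2cc(/C=C/c3ccc(OC)c(OC)c3)nc(OCCCCCBr)n2)cc1OC`. Compound 3 has the structure `BrCCCCCCOc1nc(/C=C/c2ccccc2)cc(/C=C/c2ccccc2)n1`, and compound 4, which has not yet been measured, has the structure `BrCCCCCOc1nc(/C=C/c2ccccc2)cc(/C=C/c2ccccc2)n1`. The difference between the core of compound 1 and the core of compound 3 is not broken down here.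

In a functional assay on A549 cells (Homo sapiens) for cytotoxicity, read by fluorescence and resazurin assay, with a stated time of 48 h (a higher number here means a weaker inhibitor, a lower number a stronger inhibitor), compound 1 gives > 20000 nM, which is a limit of the measurement rather than a number. In this assay compound 2 also gives > 20000 nM, again a limit. For compound 3 this assay likewise gives > 20000 nM, a limit. The change from compound 1 to compound 2 is bromo in place of bromomethyl on a saturated chain carbon, five bonds along the chain from an oxygen on an aromatic ring; the step that the two limits leave unreadable from compound 1 to compound 2 cannot be sized, since both ends sit at the limit of > 20000 nM in this assay, at which 3 of the 3 values shown sit.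

The change from compound 3 to compound 4 is bromo in place of bromomethyl on a saturated chain carbon, five bonds along the chain from an oxygen on an aromatic ring, the same change made at the same place. Compound 4 is expected to give a step that the limit leaves unreadable from compound 3 to compound 4, resting on compound 3 at > 20000 nM and on the unreadable step from compound 1 to compound 2. For compound 4 the estimated value is 30000 nM, within a range from 12000 nM to 100000 nM, most likely reported again as a limit.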

Compound 4, half-maximal inhibitory concentration: > 20000 nM
Compound 4: only a limit was reported; the forecaster's own chance of this, stated with the estimate: 85%; the middle value is on the limit's open side.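

In this assay compound 4 gives > 20000 nM, which is a limit rather than a number. Going by these compounds alone, compound 3 also sits at a limit, so no step between compound 3 and compound 4 can be read, and the pair gives no size for the change: the limit of > 20000 nM in this assay, at which 4 of the 4 values shown sit. The compounds shown leave open whether shortening the chain changes cytotoxicity at all, since none of them gives a measurable value.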